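This account rests on a few compounds, and the source may have more. Where it says the series, first, only, none or still open, it means among the compounds named here.

In a functional assay on HepG2 cells (Homo sapiens) for antiproliferative activity, read by MTT assay, with a stated time of 48 h (on this read-out higher numbers stand for weaker inhibition of growth and lower numbers for stronger inhibition of growth), compound 1 (`CCN(Cc1ccc(C(=O)NO)cc1)c1ncc(-c2ccc(C)cc2)s1`) gives 1120 nM. Compound 2 (`Cc1ccc(OCCCN(Cc2ccc(C(=O)NO)cc2)c2ncc(-c3ccc(C)cc3)s2)cc1`) gives 12200 nM, the higher of the two numbers and so the weaker inhibition of growth. Compound 3 (`Cc1ccc(-c2cnc(N(CCCCOc3ccccc3)Cc3ccc(C(=O)NO)cc3)s2)cc1`) differs from it as follows: phenoxymethyl in place of 4-methylphenoxy on a saturated chain carbon, three bonds along the chain from a nitrogen on an aromatic ring. Phenoxymethyl stands in place of 4-methylphenoxy on a saturated chain carbon, three bonds along the chain from a nitrogen on an aromatic ring, so 3-(4-methylphenoxy)propyl becomes 4-phenoxybutyl. For the measured compounds named here, the only measured step, an 11-fold higher number from compound 1 to compound 2 (1.04 log units; beyond the scatter), was large, but it put (4-methylphenoxy)methyl in place of hydrogen and does not test this exchange. Compound 3 holds the same atoms as compound 2, so it is expected to stay near compound 2, which gives 12200 nM. In this assay the expected 1.2-fold lower number from compound 2 to compound 3 (0.09 log units; within the scatter) lies within the scatter, with no firm direction. For compound 3 the estimated value is 10000 nM, with an expected range from 4000 nM to 25000 nM.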

Compound 3, concentration for 50% growth inhibition: 16600 nM
Estimate against measurement, compound 3: 1.7-fold (0.22 log units) below; measured number inside the range.
By their numbers in this assay, from the lowest: compound 1; then compounds 2 and 3 (each within the scatter of the next).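

In this assay, trading 3-(4-methylphenoxy)propyl for 4-phenoxybutyl gives a 1.4-fold higher number from compound 2 to compound 3 (0.13 log units; within the scatter) and so leaves compounds 2 and 3 indistinguishable on this read-out, even though the ring methyl is gone and the chain has been extended. Compared with the ethyl group of compound 1, the 4-phenoxybutyl group gives a 15-fold higher number from compound 1 to compound 3 (1.17 log units; beyond the scatter) and thus a large step of the same direction as the one seen for compound 2, so the weaker inhibition of growth holds for both aryl ether chains shown here. No measurement at hand accounts for this result.

Because the methyl and the chain length change together in this exchange, the contribution of each remains unresolved, and 3-phenoxypropyl or 4-(4-methylphenoxy)butyl would separate them. Going by these compounds, whether a chain ending in an amine or a carboxylic acid would behave like these aryl ethers or like the ethyl group also stays open.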